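From Pyridin-2-yl to 3-Hydroxyphenyl: Expected Cytotoxicity of Compound 4

The compounds below may be only part of what the source reports. "The series", "measured", "known", "first", "only" and "open" are said of these compounds alone.

Compound 1 `O=C(/C=C/c1ccc2c(c1)B(O)OC2)c1ccccn1` was examined in an ADME assay on L929 cells (Mus musculus) for cytotoxicity, read by resazurin assay, with a stated time of 72 h; a lower number here means a stronger inhibitor, a higher number a weaker inhibitor. In this assay compound 1 gives only a limit, > 10 ug/mL, and no number. Two related compounds were tested in the same way. Compound 2 `COc1cc(C(=O)/C=C/c2ccc3c(c2)B(O)OC3)cc(OC)c1OC` also gives only a limit in this assay, > 10 ug/mL. Compound 3 `COc1cc(C(=O)/C=C/c2ccc3c(c2)B(O)OC3)ccc1[N+](=O)[O-]` likewise gives only a limit in this assay, > 10 ug/mL. The shared picture is the limit of > 10 ug/mL in this assay, at which 3 of the 3 values shown sit, so compound 1 stands with the others at that limit, and no measured step between any pair of these compounds exists to tell its size.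

Compound 4 `O=C(/C=C/c1ccc2c(c1)B(O)OC2)c1cccc(O)c1` has not yet been measured. It differs from compound 1 in one place: 3-hydroxyphenyl in place of pyridin-2-yl on a carbonyl carbon. With the three measured compounds sitting at the limit, no change beyond the usual scatter is expected, and the step from compound 1 to compound 4 in this assay is estimated as a step that the limit leaves unreadable from compound 1 to compound 4. For compound 4 the half-maximal inhibitory concentration in this assay is expected near 15 ug/mL, with a range from 7 ug/mL to 40 ug/mL, most likely reported again as a limit.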

Compound 4, half-maximal inhibitory concentration: 7.56 ug/mL
Beside the measured number, compound 4's estimate is 2.0-fold (0.30 log units) above it; measured number inside the range.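

In this assay, 3-hydroxyphenyl in place of pyridin-2-yl on the carbonyl carbon gives the first result among the compounds shown that is a number and not a limit, so this change can be written as a step: an at least 1.3-fold lower number from compound 1 to compound 4 (0.12 log units; that floor lies within the scatter). That step is only a floor and lies within the scatter, so it does not yet show that the change alters the result. Its full size cannot be read because compound 1 remains a limit: the limit of > 10 ug/mL in this assay, at which 3 of the 4 values shown sit.

The compounds shown leave open whether the hydroxyl, the carbon-only ring or the loss of the ring nitrogen goes with the measured number. A plain phenyl on the same carbonyl carbon, or an amine or a carboxylic acid in place of the hydroxyl, would help to separate these.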